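A few compounds are considered here, and "the series" means these few. Any claim that something is new, unique, unknown or untested is made for them only; others in the source may bear on it.

Measured compounds in a functional assay on SW 1116 cells (Homo sapiens) for cytotoxicity, read by MTT assay, with a stated time of 48 h; on this read-out higher numbers stand for weaker inhibition and lower numbers for stronger inhibition:
- compound 1 `COc1ccc(/C=N/NC(=O)CSc2nnc(-c3ccncc3)o2)cc1` gives 20300 nM
- compound 2 `O=C(CSc1nnc(-c2ccncc2)o1)N/N=C/c1cc(Br)ccc1O` gives 8150 nM
- compound 3 `O=C(CSc1nnc(-c2ccncc2)o1)N/N=C/c1ccc(Cl)cc1Cl` gives 28900 nM

Among these three numbers, compound 1 stands second highest. Its nearest neighbour is compound 3, where the step of a 1.4-fold higher number from compound 1 to compound 3 (0.15 log units; within the scatter) lies within the scatter, so the two cannot be told apart. Its furthest neighbour is compound 2, reached by the step of a 2.5-fold lower number from compound 1 to compound 2 (0.40 log units; beyond the scatter), which is modest but beyond the scatter. Between the two others, the step of a 3.5-fold higher number from compound 2 to compound 3 (0.55 log units; beyond the scatter) is likewise modest.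

The new compound 4 `O=C(CSc1nnc(-c2ccncc2)o1)N/N=C/c1ccco1` differs from compound 1 as follows: furan-2-yl in place of 4-methoxyphenyl on a carbon with a double bond to nitrogen. All three measured steps replace one aromatic group by another on the same carbon with a double bond to nitrogen, and none of them changes the number by more than a modest amount; one of them stays within the scatter. Within the data shown here, no measured step introduces a five-membered aromatic ring with a hetero atom, so there is no close precedent for this particular change. On this basis compound 4 is expected to land near compound 1, with a step of a 1.0-fold lower number from compound 1 to compound 4 (0.01 log units; within the scatter) that need not exceed the scatter in either direction. The estimate for compound 4 is 20000 nM, with a range from 7000 nM to 55000 nM.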

Compound 4, half-maximal inhibitory concentration: 18800 nM
Beside the measured number, compound 4's estimate is 1.1-fold (0.03 log units) above it, within the range that was stated.
By their numbers in this assay, from the lowest: compound 2; then compounds 4, 1 and 3 (each within the scatter of the next).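

In this assay, among these compounds, compound 4 puts a five-membered aromatic ring with a hetero atom on the carbon with a double bond to nitrogen, a ring type absent from the earlier compounds, and the exchange for 4-methoxyphenyl, with 5 heavy atoms entering for 8, produces no step that can be told from the scatter (a 1.1-fold lower number from compound 1 to compound 4 (0.03 log units; within the scatter)). The exchange for 2,4-dichlorophenyl also stays within the scatter (a 1.5-fold lower number from compound 3 to compound 4 (0.19 log units; within the scatter)), so among compounds 1, 3 and 4 neither the size of the ring nor the oxygen in it separates the numbers. Among the compounds shown here, only the 5-bromo-2-hydroxyphenyl group stands apart, and the step to furan-2-yl is modest but beyond the scatter (a 2.3-fold higher number from compound 2 to compound 4 (0.36 log units; beyond the scatter)), which makes compound 2 the one compound whose steps to all the others are beyond the scatter.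

Still open, on these data alone, is whether a saturated ring such as cyclohexyl, a longer alkyl chain or a phenyl ring carrying a carboxylic acid would move the number at this carbon, and whether the hydroxyl or the bromine of compound 2 accounts for its separation. Nothing available here explains why compound 2 separates from the other three.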